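Swapping the Butoxyphenyl Arm: Cytotoxicity Outlook for Compound 4

The source may hold more compounds than are shown below. What is called first, only, known or untested is meant among the compounds shown, and "the series" means these compounds.

Measured so far:
compound 1 `CCc1ccc2cc(CN(Cc3ccc(C(C)(C)C)cc3)C3CCCC3)c(=O)[nH]c2c1`: > 9000 nM
compound 2 `CCCCOc1ccc(CN(Cc2ccc(C(C)(C)C)cc2)Cc2cc3cc(C)ccc3[nH]c2=O)cc1`: > 5000 nM
compound 3 `CCc1ccc2[nH]c(=O)c(CN(Cc3ccc(C(C)(C)C)cc3)[C@@H](C)c3ccc(F)cc3)cc2c1`: > 5000 nM

All three compounds share a common core and were tested in a toxicity assay on MDCK cells (Canis lupus familiaris) for cytotoxicity, read by crystal violet staining, with a stated time of 48 h; on this read-out higher numbers stand for lower toxicity in this test and lower numbers for higher toxicity in this test. For compound 2 the reported value > 5000 nM is a limit of the assay, not a measured number. The same holds for compound 1, whose value is also a limit. Compound 3 likewise sits at a limit. In sum, two of the three values stand at the limit of > 5000 nM in this assay, at which 2 of the 3 values shown sit, and one at the limit of > 9000 nM in this assay, at which 1 of the 3 values shown sits, so no compound shown has a toxicity that could be pinned to a number, and compound 2 stands with the others at the low-toxicity end of what the test can report.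

Compound 4 `Cc1ccc2[nH]c(=O)c(CN(Cc3ccc(C(C)(C)C)cc3)Cc3ccc(N(C)C)c(Cl)c3)cc2c1` differs from compound 2 by 3-chloro-4-(dimethylamino)phenyl in place of 4-butoxyphenyl on a saturated chain carbon bound to an amine nitrogen. Both of these groups are attached at the same position, and the rest of the molecule is unchanged. With every neighbour at a limit, the step from compound 2 to compound 4 in this assay is expected to be none beyond the scatter, as a step that the limit leaves unreadable from compound 2 to compound 4. Compound 4 is therefore estimated at 8000 nM, most likely again reported only as a limit, within 3000 nM to 30000 nM.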

Compound 4, half-maximal cytotoxic concentration: > 10000 nM
Compound 4: only a limit was reported (the forecaster's own chance of this, stated with the estimate: 70%); middle value at least 1.2-fold (0.09 log units) from the limit.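

Compound 2 and compound 4 are both reported only as limits in this assay, and the change from 4-butoxyphenyl to 3-chloro-4-(dimethylamino)phenyl gives no readable step. The compounds shown leave open the actual concentration at which any of the four becomes toxic to these cells.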